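Replacing dimethylamino on the terminal ring with two methoxy groups

This account rests on a few compounds, and the source may have more. Where it says the series, first, only, none or still open, it means among the compounds named here.

Measured in a functional assay on Gurav cells (Homo sapiens) for inhibition, read by sulforhodamine B assay; a lower number here means a stronger inhibitor of growth, a higher number a weaker inhibitor of growth:
- compound 1 `Oc1ccc(-c2ccc(-c3ccc(-c4nc5c(O)cccc5[nH]4)cc3)cc2)cc1`: 190 nM
- compound 2 `CN(C)c1ccc(-c2ccc(-c3ccc(-c4nc5c(O)cccc5[nH]4)cc3)cc2)cc1`: 8210 nM

Of these two numbers, compound 2 has the higher, at 8210 nM. Among the compounds with values here, its only neighbour is compound 1, at 190 nM, and the gap between them lies well beyond the scatter.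

The next structure is compound 3 `COc1ccc(-c2ccc(-c3ccc(-c4nc5c(O)cccc5[nH]4)cc3)cc2)cc1OC`. The change is 3,4-dimethoxyphenyl in place of 4-(dimethylamino)phenyl on an aromatic carbon, so 3,4-dimethoxyphenyl stands in place of 4-(dimethylamino)phenyl on an aromatic carbon.

Within the data shown here, only one measured step bears on this change: a 43-fold higher number from compound 1 to compound 2 (1.64 log units; beyond the scatter). That large step came with dimethylamino in place of hydroxy, and compound 3 likewise loses the dimethylamino group. Among the measured compounds shown here, no measured compound carries methoxy, however, and compound 3 does not regain the hydroxy of compound 1, so only a partial return toward 190 nM seems reasonable, and this is uncertain.

In this assay, the expected change is a moderate drop beyond the scatter, a 5.1-fold lower number from compound 2 to compound 3 (0.71 log units; beyond the scatter). For compound 3 the estimated value is 1600 nM, with an expected range of 350 nM to 7000 nM.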

Compound 3, concentration for 50% growth inhibition: 1110 nM
Estimate against measurement, compound 3: 1.4-fold (0.16 log units) above; the range from low to high includes it.
By their numbers in this assay, from the lowest: compound 1; then compound 3; then compound 2.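

In this assay, 3,4-dimethoxyphenyl in place of 4-(dimethylamino)phenyl gives a 7.4-fold lower number from compound 2 to compound 3 (0.87 log units; beyond the scatter), so much of the loss seen with dimethylamino at this place on the terminal ring is recovered without restoring the hydroxy group. The recovery is only partial: 3,4-dimethoxyphenyl in place of 4-hydroxyphenyl gives a 5.8-fold higher number from compound 1 to compound 3 (0.77 log units; beyond the scatter), which leaves compound 1 the strongest inhibitor of growth of the three and shows that the two replacements for its 4-hydroxyphenyl group are not equivalent in this assay. No measurement is available that explains why these terminal groups rank as they do.

The compounds shown leave open whether both methoxy groups are needed for the recovery, since the two enter together and a single methoxy group is not among these compounds. They also leave open how a primary amine or a carboxylic acid on the same ring would rank against hydroxy, and therefore whether the order seen here extends beyond these three terminal groups.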